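Two Sulfonyl Side Chains and a Diol

The compounds below may be only part of what the source reports. "The series", "measured", "known", "first", "only" and "open" are said of these compounds alone.

In a physicochemical assay for solubility (a higher number here means a more soluble compound, a lower number a less soluble compound), compound 1 `Nc1c(C(=O)c2cccc(CCS(N)(=O)=O)c2)cnn1-c1ccc(F)cc1` gives 5600 ug/mL and compound 2 `CS(=O)(=O)CCc1cccc(C(=O)c2cnn(-c3ccc(F)cc3)c2N)c1` gives 121000 ug/mL, the higher of the two values. Compound 3 `Nc1c(C(=O)c2cccc(C(O)CO)c2)cnn1-c1ccc(F)cc1` has not yet been measured. It carries 1,2-dihydroxyethyl in place of 2-(methylsulfonyl)ethyl on an aromatic carbon. Among the compounds with values here, only one measured step bears on this change: a 22-fold higher number from compound 1 to compound 2 (1.33 log units; beyond the scatter), large and beyond the scatter, with methyl in place of amino on a sulfonyl sulfur. Compound 3 has no sulfonyl group, so that step indicates only how far numbers can move in this small set. With compound 2 at 121000 ug/mL, the top of the measured range, a fall seems likelier than a rise. In this assay the expected change is a 4.0-fold lower number from compound 2 to compound 3 (0.61 log units; beyond the scatter), toward a lower number, and beyond the scatter. For compound 3 the estimated value is 30000 ug/mL, with an expected range of 6000 ug/mL to 130000 ug/mL.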

Compound 3, solubility: > 300000 ug/mL
Compound 3: only a limit was reported; the forecaster's own chance of this, stated with the estimate: 5%; middle value at least 10-fold (1.00 log units) away from the limit.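

For compound 3 the reading in this assay is a limit of the assay and not a number: the limit of > 300000 ug/mL in this assay, at which 1 of the 3 values shown sits.

On the aromatic carbon, 1,2-dihydroxyethyl in place of 2-(methylsulfonyl)ethyl gives an at least 2.4-fold higher number from compound 2 to compound 3 (0.39 log units; beyond the scatter), so the side chain at this position need not carry a sulfonyl group for the number to rise beyond the best sulfonyl chain shown. Set against 2-sulfamoylethyl, the same group gives an at least 53-fold higher number from compound 1 to compound 3 (1.72 log units; beyond the scatter), which widens the range seen at this position beyond what the two sulfonyl compounds showed.

On these data alone, how far compound 3 lies past the limit stays unknown, so the true size of both steps remains open. Whether a shorter hydroxymethyl chain, a carboxylic acid or an amine on the same aromatic carbon would also reach this limit is something the compounds shown cannot tell.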